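The source may report more compounds than this note shows. Statements on the series, on what has been measured and on what is new or still open speak of the compounds shown alone.

For the measured compounds named here, in a functional assay on MCF7 cells (Homo sapiens) for inhibition, read by MTT assay, with a stated time of 72 h (a higher number here means a weaker inhibitor, a lower number a stronger inhibitor), only two compounds have been measured so far. Compound 1 `CSCC[C@H](NC(=O)c1cc(Cl)ccc1OCCN)C(=O)Nc1ccc([N+](=O)[O-])cc1Cl` gives > 10000 nM, which is a limit of the assay and not a number. Compound 2 `CC(C)(C)OC(=O)CC[C@H](NC(=O)c1cc(Cl)ccc1OCCNC(=O)OC(C)(C)C)C(=O)Nc1ccc([N+](=O)[O-])cc1Cl` gives > 10000 nM, and this too is a limit and not a number. Going by the values given here, the whole record so far is the limit of > 10000 nM in this assay, at which 2 of the 2 values shown sit, so compound 2 stands at the limit and no measured step is available for comparison.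

Compound 3 `CC(C)(C)OC(=O)CC[C@H](NC(=O)c1cc(Cl)ccc1OCCN)C(=O)Nc1ccc([N+](=O)[O-])cc1Cl` has hydrogen in place of tert-butoxycarbonyl on an amine nitrogen of compound 2: hydrogen in place of tert-butoxycarbonyl on an amine nitrogen. Among the compounds with values here, no measured pair shows what this change does in this assay, so any forecast is uncertain. Starting from compound 2 at the limit of > 10000 nM, no step beyond the scatter is expected, and compound 3 is expected to remain a weak inhibitor, quite possibly reported only as a limit. The expected change is a step that the limit leaves unreadable from compound 2 to compound 3. For compound 3 the estimated half-maximal inhibitory concentration is 12000 nM, with an expected range of 4000 nM to 40000 nM.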

Compound 3, half-maximal inhibitory concentration: 3080 nM
The estimate for compound 3 lay 3.9-fold (0.59 log units) above the measured number, and the stated range ends above it.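

For the compounds shown here, compound 3 is the first compound in this assay to give a number and not a limit, so this amine nitrogen is now a place where a change can be read. Hydrogen in place of tert-butoxycarbonyl there gives an at least 3.2-fold lower number from compound 2 to compound 3 (0.51 log units; beyond the scatter) and the second comparison, tert-butoxycarbonyl in place of methylsulfanyl on the saturated chain carbon with the 2-aminoethyl group kept, gives an at least 3.2-fold lower number from compound 1 to compound 3 (0.51 log units; beyond the scatter) in the same assay. So the number appears only where the free 2-aminoethyl group and the tert-butoxycarbonyl on the chain occur together, while compound 1 and compound 2 each carry only one of these and both remain at a limit and not a number: the limit of > 10000 nM in this assay, at which 2 of the 3 values shown sit.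

As far as these compounds go, both steps start from that limit, so their true sizes remain unknown, and a single compound with a number cannot show how far either place can be pushed. The compounds shown leave open whether a carboxylic acid in place of the tert-butoxycarbonyl on the chain, or a longer chain between the ether oxygen and the amine, would move the number in this assay further.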